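Dropping the Drawn Configuration at the Ring Stereocentre

The source may hold more compounds than are shown below. What is called first, only, known or untested is meant among the compounds shown, and "the series" means these compounds.

Of the compounds shown here, three built on a shared core have been tested in a functional assay on CHO cells for agonist activity at Melanocortin receptor 4 (Homo sapiens), read by a luciferase reporter, with a stated time of 4 h; a lower number here means that less compound is needed, a higher number that more compound is needed for the effect. Compound 1 `CC(C)N(C(=O)CN1C=CN(c2ccccc2)C(=O)[C@H](Cc2n[nH]c3ccccc23)C1=O)c1ccccc1` gives 1070 nM. Compound 2 `COc1ccc(N(C(=O)CN2C=CN(c3cccnc3)C(=O)C(Cc3n[nH]c4ccccc34)C2=O)C(C)C)cc1`, which carries different aromatic groups at two places, gives 2880 nM. Compound 3 `CC(C)N(C(=O)CN1C=CN(c2ccccc2)C(=O)[C@H](Cc2n[nH]c3cc(F)ccc23)C1=O)c1ccccc1` gives 1260 nM. Among these three numbers compound 3 stands second highest; the step of a 1.2-fold higher number from compound 1 to compound 3 (0.07 log units; within the scatter) shows that the added fluorine changed little, while compound 2 sits further off with a higher number.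

Compound 4 `CC(C)N(C(=O)CN1C=CN(c2ccccc2)C(=O)C(Cc2n[nH]c3cc(F)ccc23)C1=O)c1ccccc1` comes next. Relative to compound 3 the difference is this: the two compounds have the same atoms and bonds; at least one stereo element is drawn with a configuration in one of them and without one in the other: 1 of 1 stereo elements differ; a stereocentre at a saturated ring carbon is drawn R in compound 3 and without a configuration in compound 4. Within the data shown here, no measured step in this set concerns a change of drawn configuration alone; the single measured step, a 1.2-fold higher number from compound 1 to compound 3 (0.07 log units; within the scatter), is a different kind of change and offers no guide. A compound drawn without configuration may be a mixture of both forms, so in this assay the same or a somewhat higher number is expected. The expected step is a 1.4-fold higher number from compound 3 to compound 4 (0.15 log units; within the scatter). Compound 4 is estimated at 1800 nM, within a range from 900 nM to 4000 nM.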

Compound 4, half-maximal effective concentration: 537 nM
Compound 4: middle estimate off by 3.4-fold (0.53 log units), on the high side, and the stated range ends above it.
By their numbers in this assay, from the lowest: compounds 4, 1 and 3 (each within the scatter of the next, the first and the last beyond it); then compound 2.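

Unlike the fluorine swap, a 1.2-fold higher number from compound 1 to compound 3 (0.07 log units; within the scatter), the step of a 2.3-fold lower number from compound 3 to compound 4 (0.37 log units; beyond the scatter) lies beyond the scatter, so in this assay the way this saturated ring carbon is drawn counts for more than that added fluorine. The atoms and bonds are the same in both compounds, so this step can be traced to one thing only: the fact that one of compounds 3 and 4 is drawn with a defined configuration and the other without, at the place where they differ. If compound 4 is a mixture of both forms, the form not drawn in compound 3 would have to contribute to the lower number, so the R form would not be the better of the two at this carbon.

As far as these compounds go, what compound 4 actually contains, and what the S form alone would give, stays open. So does the effect of a methyl group in place of the hydrogen on this ring carbon.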